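A few compounds are considered here, and "the series" means these few. Any claim that something is new, unique, unknown or untested is made for them only; others in the source may bear on it.

Values in a functional assay on the whole organism (strain Kunming) with Mus musculus as the target, with a stated time of 0.5 h; a lower number here means that less compound is needed, a higher number that more compound is needed for the effect
compound 1 `COc1cc(OC)c(OC)cc1/C=C/COC(=O)/C=C/c1cc(OC)c(OC)c(OC)c1OC` gives 155 mg/kg
compound 2 `COc1cc(OC)c(OC)cc1/C=C/COC(=O)/C=C/c1ccc(Br)cc1` gives 193 mg/kg
compound 3 `COc1cc(OC)c(OC)cc1/C=C/COC(=O)/C=C/c1cc(OC)c(OC)c(OC)c1` gives 204 mg/kg

Compound 2 lies within the scatter of both compound 1 and compound 3, so the three values carry no order. Compound 4 `COc1cc(OC)c(OC)cc1/C=C/COC(=O)/C=C/c1ccc(F)cc1` is still unmeasured and differs from compound 2 by fluoro in place of bromo on an aromatic carbon. For the measured compounds named here, no measured step covers this exchange. Going by the values given here, the only measured step (a 1.3-fold higher number from compound 1 to compound 3 (0.12 log units; within the scatter)) is hydrogen in place of methoxy on an aromatic carbon, stays within the scatter and bears only loosely on the change. Compound 2 (193 mg/kg) is therefore the anchor, and no shift beyond the scatter is expected in this assay in either direction. The expected step is small (a 1.0-fold lower number from compound 2 to compound 4 (0.01 log units; within the scatter)). For compound 4 the estimated value is 190 mg/kg (expected range 110 mg/kg to 320 mg/kg).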

Compound 4, dose for half-maximal effect: 167 mg/kg
Beside the measured number, compound 4's estimate is 1.1-fold (0.06 log units) above it; the measured number falls inside the stated range.
By their numbers in this assay, from the lowest: compounds 1, 4, 2 and 3 (each within the scatter of the next).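

In this assay, the exchange of 4-bromophenyl for 4-fluorophenyl gives a 1.2-fold lower number from compound 2 to compound 4 (0.06 log units; within the scatter), so replacing one halogen with another at this position leaves the number within the scatter. For the compounds shown here, the only earlier step concerned hydrogen in place of methoxy, so this is the first direct reading of a halogen exchange. Nothing available explains this result or links it to a measured property of either group. On these data alone, it remains open whether an amine, a carboxylic acid or a nitrile at this position would move the number beyond the scatter. As far as these compounds go, the effect of changes to the shared ester linker also remains open.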